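From dimethylamino to azido on compound 2

This account rests on a few compounds, and the source may have more. Where it says the series, first, only, none or still open, it means among the compounds named here.

In a functional assay on MCF7 cells (Homo sapiens) for antiproliferative activity, read by MTT assay, with stated times of 24 h and 72 h (a lower number here means a stronger inhibitor, a higher number a weaker inhibitor), compound 1 `COc1ccc([C@@H]2[C@@H](Oc3ccccc3)C(=O)N2c2cc(OC)c(OC)c(OC)c2)cc1` gives 6900 nM and compound 3 `COc1ccc([C@@H]2[C@@H](Oc3ccccc3)C(=O)N2c2cc(OC)c(OC)c(OC)c2)cc1[N+](=O)[O-]` gives 4100 nM. Compound 2 `COc1cc(N2C(=O)[C@@H](Oc3ccccc3)[C@H]2c2ccc(N(C)C)cc2)cc(OC)c1OC` gives 31000 nM, the highest of the three numbers and beyond the scatter of both others. Compound 4 `COc1cc(N2C(=O)[C@@H](Oc3ccccc3)[C@H]2c2ccc(N=[N+]=[N-])cc2)cc(OC)c1OC` carries azido in place of dimethylamino on an aromatic carbon. Going by the values given here, no measured step makes this exchange. The only one measured, a 1.7-fold lower number from compound 1 to compound 3 (0.23 log units; within the scatter), puts nitro in place of hydrogen and offers weak guidance. Only compound 2 carries dimethylamino, so losing it is expected to move the number down, towards the other two. The expected change is a 3.1-fold lower number from compound 2 to compound 4 (0.49 log units; beyond the scatter). For compound 4 the estimate is 10000 nM, with an expected range of 3000 nM to 30000 nM.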

Compound 4, half-maximal inhibitory concentration: 23000 nM
Compound 4: middle estimate off by 2.3-fold (0.36 log units), on the low side; the range from low to high includes it.
By their numbers in this assay, from the lowest: compounds 3 and 1 (each within the scatter of the next); then compounds 4 and 2 (each within the scatter of the next).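

In this assay, azido in place of dimethylamino gives a 1.3-fold lower number from compound 2 to compound 4 (0.13 log units; within the scatter) and so leaves the number unchanged within the usual scatter. This is the first exchange shown at this position on the ring, and it shows that removing dimethylamino does not by itself bring the number down. Compound 4 stays level with compound 2 even though the two groups differ in their atoms. Nothing measured here bears on why these two groups read alike. From the compounds shown here alone, whether a primary amine or a carboxylic acid at this position would also stay level with compound 2 remains open.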